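Methyl for Fluoro: Expecting Little Change in Binding

This account rests on a few compounds, and the source may have more. Where it says the series, first, only, none or still open, it means among the compounds named here.

Two close relatives of one shared core have been tested in an assay on CHO cells for displacement of a labelled ligand from 5-hydroxytryptamine receptor 7 (Homo sapiens); a higher number here means a weaker inhibitor, a lower number a stronger inhibitor. Compound 1 `CCC1(CCCCN2CCN(c3ccc(Cl)cc3)CC2)C(=O)Nc2ccccc21` gives 0.38 nM; 0.38 nM (2 entries) in this assay. Within the data shown here, compound 2 `CCC1(CCCCN2CCN(c3ccc(F)c(Cl)c3)CC2)C(=O)Nc2ccccc21` gives 0.6 nM in this assay; this is the only number known for compound 2, since a further entry for it carries no single number. Compound 3 `CCC1(CCCCN2CCN(c3ccc(C)c(Cl)c3)CC2)C(=O)Nc2ccccc21` has not yet been tested. It differs from compound 2 by a single change: methyl in place of fluoro on an aromatic carbon. Among the measured compounds shown here, no measured pair isolates this exact swap, so any expectation rests on the two numbers above, both of which show strong binding from the same core and side chain. Exchanging one small group for another at this spot is expected to shift the result by a 1.3-fold higher number from compound 2 to compound 3 (0.12 log units; within the scatter), a step that may well stay inside the usual scatter. Compound 3 is therefore estimated at 0.8 nM, with a plausible range from 0.3 nM to 2.5 nM.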

Compound 3, inhibition constant: 0.66 nM
Beside the measured number, compound 3's estimate is 1.2-fold (0.08 log units) above it; low and high end bracket the measured number.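

Among these compounds, measured in this assay, replacing fluoro with methyl gives a 1.1-fold higher number from compound 2 to compound 3 (0.04 log units; within the scatter), the first reading for a pair that differs only at this carbon. Among the compounds shown here, at this position, ortho to a chloro group and para to a large group, the assay therefore does not distinguish a fluoro from a methyl, and both compounds keep the strong binding seen across the series so far. Nothing measured here speaks to why the two groups read alike.

The compounds shown leave open how binding responds to a different kind of group at this same carbon, such as an amine, a hydroxyl group or a carboxylic acid, or to a longer chain such as propyl. A single pair also cannot tell whether fluoro and methyl would still match without the chloro group or on another core.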